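Cyclopentylamino for chloro on the fused core, cytotoxicity

This account rests on a few compounds, and the source may have more. Where it says the series, first, only, none or still open, it means among the compounds named here.

Compound 2 `COc1cccc(-c2nc3c(Cl)cccn3c2-c2ccnc(NC3CCCC3)n2)c1` stands at the assay limit in an ADME assay on Vero cells (Chlorocebus sabaeus) for cytotoxicity; a higher number here means that more compound is tolerated, a lower number that less compound is tolerated: compound 2 gives > 40000 nM, a limit rather than a number. Compound 1 `C=CCOc1ccc(-c2nc3c(NC4CCCC4)cccn3c2-c2ccnc(NC3CCCC3)n2)cc1` is also reported only as a limit in this assay, compound 1 giving > 40000 nM. Both values sit at the same ceiling (the limit of > 40000 nM in this assay, at which 2 of the 2 values shown sit). Compound 3 `COc1cccc(-c2nc3c(NC4CCCC4)cccn3c2-c2ccnc(NC3CCCC3)n2)c1` differs from compound 2 by cyclopentylamino in place of chloro on an aromatic carbon. No step beyond the scatter is expected in this assay, since compound 1 already carries cyclopentylamino at that place and shows > 40000 nM. Compound 3 is expected at 50000 nM, range 25000 nM to 100000 nM, a step that the limit leaves unreadable from compound 2 to compound 3.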

Compound 3, half-maximal cytotoxic concentration: > 40000 nM
Compound 3 gave a limit, no number; the forecaster's own chance of this, stated with the estimate: 85%; the middle value does not contradict the limit.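

Compound 1, compound 2 and compound 3 all give limits in this assay, so no step can be read between them: the limit of > 40000 nM in this assay, at which 3 of the 3 values shown sit.

Whether either change between these compounds shifts the tolerated concentration stays open, with no number among the compounds shown.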